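From one methyl to two on the aromatic ring

The source may hold more compounds than are shown below. What is called first, only, known or untested is meant among the compounds shown, and "the series" means these compounds.

- compound 1 `COC1=C(C)C(=O)/C(=C(O)/C=C/c2ccc(Br)cc2)C(=O)C1(C)C` gives 3.6 ug/mL
- compound 2 `COC1=C(C)C(=O)/C(=C(O)/C=C/c2ccc(C)cc2)C(=O)C1(C)C` gives 2.4 ug/mL
- compound 3 `CCc1ccc(/C=C/C(O)=C2/C(=O)C(C)=C(OC)C(C)(C)C2=O)cc1` is recorded as "not determined" (no result reported)

These numbers come from a functional assay on HUVEC cells (Homo sapiens) for cytotoxicity (a lower number here means that less compound is needed, a higher number that more compound is needed for the effect), and compound 3 offers no guide without a number. Compound 2 at 2.4 ug/mL and compound 1 at 3.6 ug/mL lie within the scatter of each other, so compound 2 holds no clear rank on the two numbers available.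

The next compound to be measured is compound 4 `COC1=C(C)C(=O)/C(=C(O)/C=C/c2cc(C)cc(C)c2)C(=O)C1(C)C` and it differs from compound 2 by one change: 3,5-dimethylphenyl in place of 4-methylphenyl on a double-bonded chain carbon bound to a double-bonded chain carbon while the shared core stays the same. Within the data shown here, no measured compound carries a 3,5-dimethylphenyl group, so there is no direct precedent for it. Among the measured compounds shown here, only one measured step offers even indirect guidance: a 1.5-fold lower number from compound 1 to compound 2 (0.18 log units; within the scatter) with methyl in place of bromo on an aromatic carbon. That step did not rise above the scatter, and a single small step is thin evidence, so no real shift in either direction is expected here.

The estimated step is a 1.0-fold higher number from compound 2 to compound 4 (0.02 log units; within the scatter) and this is not expected to exceed the scatter. For compound 4 the expected value in this assay is 2.5 ug/mL with an estimated range from 1.2 ug/mL to 5 ug/mL for a single measurement.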

Compound 4, concentration for half-maximal effect: 2.5 ug/mL
Beside the measured number, compound 4's estimate shows no gap at the digits printed; the range from low to high includes it.
By their numbers in this assay, from the lowest: compounds 2, 4 and 1 (each within the scatter of the next).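

In this assay the added ring methyl gives a 1.0-fold higher number from compound 2 to compound 4 (0.02 log units; within the scatter) and replacing the bromo-substituted ring gives a 1.4-fold lower number from compound 1 to compound 4 (0.16 log units; within the scatter) so neither new step rises above the scatter. Among these compounds, the earlier compounds compared only two rings with a single substituent each, whereas this result shows that a ring with two methyl groups, arranged as 3,5-dimethylphenyl, can also sit on a double-bonded chain carbon bound to a double-bonded chain carbon without a readable change in the number. No measurement here offers an explanation for this flat result.

All three compounds with numbers carry only a bromo or methyl substituent on the phenyl ring, and compound 3 adds no number, so these results cannot show how far this tolerance extends. A ring bearing an amine or a carboxylic acid, or a longer chain in place of the methyl groups, could behave quite differently, and the numbers for compound 1, compound 2 and compound 4 give no way to predict such a result.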